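This account rests on a few compounds, and the source may have more. Where it says the series, first, only, none or still open, it means among the compounds named here.

Compound 2 `COc1cc2c(Oc3ccc(NC(=O)c4nn(-c5cccc(F)c5)c(=O)cc4C)cc3F)ccnc2cc1OCCCN1CCCC1` gives 1700 nM in a functional assay on U-87MG ATCC cells (Homo sapiens) for inhibition, read by MTT assay, with a stated time of 72 h; on this read-out higher numbers stand for weaker inhibition and lower numbers for stronger inhibition. Within the data shown here, of the two compounds measured so far it holds the higher number; its nearest neighbour is compound 1 `COc1cc2c(Oc3ccc(NC(=O)c4nn(-c5ccccc5)c(=O)cc4C)cc3F)ccnc2cc1OCCCN1CCCC1`, which in this assay gives 1100 nM, and the gap between them, a 1.5-fold higher number from compound 1 to compound 2 (0.19 log units; within the scatter), lies within the scatter. Compound 3 `COc1cc2c(Oc3ccc(NC(=O)c4nn(-c5ccc(Cl)cc5)c(=O)cc4C)cc3F)ccnc2cc1OCCCN1CCCC1` has not yet been measured. It differs from compound 2 in one place: 4-chlorophenyl in place of 3-fluorophenyl on an aromatic nitrogen. Among the measured compounds shown here, the only measured step that touches this part of the molecule is a 1.5-fold higher number from compound 1 to compound 2 (0.19 log units; within the scatter), which added a fluorine to the same phenyl ring on the ring nitrogen and changed the number by less than the scatter allows one to read. For the measured compounds named here, no measured step shows a chlorine on this ring, nor a swap between the two ring positions, so the expectation must rest on that single step. Compound 3 is therefore expected to sit close to compound 2, with a 1.1-fold lower number from compound 2 to compound 3 (0.05 log units; within the scatter) as the estimated step, and the estimate for compound 3 in this assay is 1500 nM, within a range from 500 nM to 4500 nM.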

Compound 3, half-maximal inhibitory concentration: 1430 nM
The estimate for compound 3 lay 1.0-fold (0.02 log units) above the measured number; low and high end bracket the measured number.
By their numbers in this assay, from the lowest: compounds 1, 3 and 2 (each within the scatter of the next).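

In this assay, the swap of 3-fluorophenyl for 4-chlorophenyl on the aromatic nitrogen gives a 1.2-fold lower number from compound 2 to compound 3 (0.08 log units; within the scatter), and chloro in place of hydrogen on the phenyl ring of compound 1 gives a 1.3-fold higher number from compound 1 to compound 3 (0.11 log units; within the scatter). The earlier pair had shown this only for fluoro; these steps extend it to a second halogen at a different place on the ring, and within the three compounds none goes against this, as neither step lies beyond the scatter. No evidence is available that bears on this result.

The step between compound 2 and compound 3 changes the halogen and its place on the ring together, so the compounds shown cannot separate the two. They also leave open whether a group other than a single halogen on this phenyl ring, such as an amine, a carboxylic acid or a methoxy group, or a pyridine ring or plain methyl group in place of the phenyl ring on the nitrogen, would move the number beyond the scatter.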